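The compounds below may be only part of what the source reports. "The series", "measured", "known", "first", "only" and "open" are said of these compounds alone.

Measured compounds:
compound 1 `CCOC(=O)C1=C(NN=C(C#N)C#N)Nc2[nH]nc(C)c2C1c1ccc(N(C)C)cc1` — 12100 nM in a functional assay on MCF7 cells (Homo sapiens) for inhibition, read by MTT assay, with a stated time of 48 h; a lower number here means a stronger inhibitor, a higher number a weaker inhibitor
compound 2 `CCOC(=O)C1=C(N/N=C(/C(C)=O)C(=O)OCC)Nc2[nH]nc(C)c2C1c1ccc(N(C)C)cc1` — > 100000 nM in this assay

Compound 2 sits at the limit of this assay: its reading of > 100000 nM is a bound of the assay, not a number, as the limit of > 100000 nM in this assay, at which 1 of the 2 values shown sits, records. Of the two measured compounds it is therefore the one with only a ceiling, while compound 1 has a number.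

The next compound, compound 3 `CCOC(=O)C1=C(N)Nc2[nH]nc(C)c2C1c1ccc(N(C)C)cc1`, differs from compound 2 by a hydrogen atom in place of a group of 10 heavy atoms (6 carbon, 1 nitrogen, 3 oxygen; no ring), on an amine nitrogen. Among the compounds with values here, the only measured step on that same nitrogen is an at least 8.2-fold higher number from compound 1 to compound 2 (0.91 log units; beyond the scatter), in which a larger group replacing a smaller one gave a weaker compound. Compound 3 goes the other way, shedding the group entirely and leaving a bare hydrogen, so the change is not a reversal of that step but a further shrinkage past compound 1. Whether the bare amine recovers potency toward compound 1 or stays weak cannot be told from the two points; a value between them is the plainest reading.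

Compound 3 is therefore expected to come in at 30000 nM in this assay, within 8000 nM to 150000 nM, which would be a step of an at least 3.3-fold lower number from compound 2 to compound 3 (0.52 log units; beyond the scatter) by estimate.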

Compound 3, half-maximal inhibitory concentration: 5060 nM
Compound 3: middle estimate off by 5.9-fold (0.77 log units), on the high side, and the stated range ends above it.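

On an amine nitrogen whose other neighbours are a double-bonded ring carbon, the bare hydrogen gives the lowest number of the three compounds in this assay with an at least 19-fold lower number from compound 2 to compound 3 (1.29 log units; beyond the scatter) and a 2.4-fold lower number from compound 1 to compound 3 (0.38 log units; beyond the scatter) as its two steps. Neither of the two larger groups on this nitrogen is therefore needed for the activity seen in this series; in these three compounds, each one goes with a higher number than hydrogen, and no compound shown goes against this. The larger of the two steps has no fixed size, and only its lower bound can be read, because compound 2 is recorded only as a limit: the limit of > 100000 nM in this assay, at which 1 of the 3 values shown sits.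

The compounds shown leave open whether a small group on this nitrogen, such as methyl or acetyl, would hold, lower or raise the number set by compound 3. They also leave open how much of the remaining activity depends on the rest of the shared core, for instance on the ethyl ester compared with a carboxylic acid or on the dimethylamino group compared with a plain hydrogen.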